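Swapping Fluoro for Iodo on a Phenylurea

The source may report more compounds than this note shows. Statements on the series, on what has been measured and on what is new or still open speak of the compounds shown alone.

Two ureas built on the same core have been tested so far. Compound 1 `C[C@H](NC(=O)Nc1ccc(C(C)(C)C)cc1)c1ccccc1` carries a tert-butyl group on its aromatic ring, and in an ADME assay on the whole organism with Oryza sativa as the target, tested at 0.1 uM (a higher number here means a weaker effect of the compound at the concentration tested, a lower number a stronger effect), compound 1 gives 100%. Compound 2 `C[C@H](NC(=O)Nc1ccc(F)cc1)c1ccccc1` is the same molecule with fluoro in place of tert-butyl on an aromatic carbon, and in this assay compound 2 gives 96%. Going by the values given here, the only measured step, a number 4 percentage points lower from compound 1 to compound 2 (within the scatter), is a change too small to separate from the noise of repeated runs, so compound 2 and compound 1 sit together at the top of the scale.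

The next compound, compound 3 `C[C@H](NC(=O)Nc1ccc(I)cc1)c1ccccc1`, changes the same position again: iodo in place of fluoro on an aromatic carbon. Among the compounds with values here, the one step that bears on this exchange, a number 4 percentage points lower from compound 1 to compound 2 (within the scatter), shows that replacing the group at this position has so far left the read-out essentially unchanged, so the step of a number 1 percentage points higher from compound 2 to compound 3 (within the scatter) is expected to stay within the scatter. For compound 3 the estimated read-out in this assay is 97%, with a range from 86% to 100%.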

Compound 3, a percentage reported as activity, at one concentration (the size of the read-out at that concentration, not a potency): 99%
Beside the measured number, compound 3's estimate is 2 percentage points below it; measured number inside the range.
By their numbers in this assay, from the lowest: compounds 2, 3 and 1 (each within the scatter of the next).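

With iodo in this position, compound 3 gives a third group on the same aromatic carbon, and the read-out in this assay still does not separate the compounds: the exchange of fluoro for iodo is a number 3 percentage points higher from compound 2 to compound 3 (within the scatter), and the exchange of tert-butyl for iodo is a number 1 percentage points lower from compound 1 to compound 3 (within the scatter). Compounds 1, 2 and 3 therefore cannot be told apart in this assay, so a single heavy atom of fluorine, a single heavy atom of iodine and a tert-butyl group give the same result here within the scatter, and this holds for these three groups only. No experimental information is available to explain why the three numbers stay together.

The compounds shown leave open whether a different kind of group at this position, such as an amine, a carboxylic acid or a longer chain, would give a number clearly apart from these three. They also leave open whether a change elsewhere on the shared core, rather than at this one aromatic carbon, would move the read-out beyond the scatter.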